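From 2-methylphenyl to 2,4-difluorobenzyl on the amide

The compounds below may be only part of what the source reports. "The series", "measured", "known", "first", "only" and "open" are said of these compounds alone.

In a functional assay (QGY7701 cells, Homo sapiens) for inhibition, read by MTT assay, with a stated time of 48 h (a higher number here means a weaker inhibitor, a lower number a stronger inhibitor), compound 1 `COc1ccc2c(=O)c(/C=C/C(=O)Nc3cccc(Cl)c3)coc2c1` reads > 100000 nM, which is a limit and not a number. Going by the values given here, compound 2 `COc1ccc2c(=O)c(/C=C/C(=O)Nc3ccccc3C)coc2c1` gives 22500 nM, the only true number so far. Compound 3 `COc1ccc2c(=O)c(/C=C/C(=O)NCc3ccc(F)cc3F)coc2c1` has 2,4-difluorobenzyl in place of 2-methylphenyl on an amide-type nitrogen. Among the compounds with values here, the one measured step, an at least 4.4-fold lower number from compound 1 to compound 2 (0.64 log units; beyond the scatter), shows that a change at this place can move the number, but it gives no direction for 2,4-difluorobenzyl. The expected step is therefore small, within the scatter: a 1.3-fold higher number from compound 2 to compound 3 (0.12 log units; within the scatter). For compound 3 the estimate is 30000 nM, with an expected range from 10000 nM to 100000 nM.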

Compound 3, half-maximal inhibitory concentration: > 100000 nM
Compound 3 gave a limit, no number; the forecaster's own chance of this, stated with the estimate: 25%; middle value at least 3.3-fold (0.52 log units) away from the limit.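

In this assay, 2,4-difluorobenzyl in place of 2-methylphenyl on the amide-type nitrogen gives an at least 4.4-fold higher number from compound 2 to compound 3 (0.64 log units; beyond the scatter). Of the three groups shown at this place, only 2-methylphenyl gives a true number, and the other two stop at a limit: the limit of > 100000 nM in this assay, at which 2 of the 3 values shown sit. The values of compound 1 and compound 3 are both limits, so the step between them cannot be read.

Whether the fluorines or the benzyl link accounts for the rise stays open. So does whether a plain benzyl or a longer chain ending in an amine would read lower than compound 2.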